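This account rests on a few compounds, and the source may have more. Where it says the series, first, only, none or still open, it means among the compounds named here.

Three compounds were tested in a functional assay on U-87MG ATCC cells for antiproliferative activity against U-87 MG (Homo sapiens), read by MTT assay, with a stated time of 48 h, tested at 50 uM; on this read-out higher numbers stand for a weaker effect at the one concentration tested and lower numbers for a stronger effect. Compound 3 `Cc1nc(-c2ccc(Cl)cc2)sc1C(=O)CSc1nc(-c2ccc(Cl)cc2)c(C#N)c(=O)[nH]1` gives 60%. Compound 1 `COc1ccc(-c2nc(C)c(C(=O)CSc3nc(-c4ccc(Cl)cc4)c(C#N)c(=O)[nH]3)s2)cc1` gives 48%. Compound 2 `Cc1nc(-c2ccc(Cl)cc2)sc1C(=O)CSc1nc(N)c(C#N)c(-c2ccc(Cl)cc2)n1` gives 15.5%, the lowest of the three. The difference between the cores of compound 2 and compound 3 is not broken down here. Compound 1 differs from compound 3 by methoxy in place of chloro on an aromatic carbon, and this gave a number 12 percentage points lower from compound 3 to compound 1 (beyond the scatter). Compound 4 `COc1ccc(-c2nc(SCC(=O)c3sc(-c4ccc(Cl)cc4)nc3C)nc(N)c2C#N)cc1` has not yet been tested; it differs from compound 2 by methoxy in place of chloro on an aromatic carbon, the same change, at the same place. The step from compound 2 to compound 4 is expected to be a number 7.5 percentage points lower from compound 2 to compound 4 (within the scatter), similar in direction but probably smaller, because compound 2 already stands at 15.5% and there is little room left for a lower number. The expected value for compound 4 is therefore 8%, with a range from 0% to 22%.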

Compound 4, a percentage reported as activity, at one concentration (the size of the read-out at that concentration, not a potency): 17.8%
Estimate against measurement, compound 4: 9.8 percentage points below, and the stated range covers the measured number.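

In this assay, going from 4-chlorophenyl to 4-methoxyphenyl on the core of compound 2 gave a number 2.3 percentage points higher from compound 2 to compound 4 (within the scatter), so no real effect can be claimed on this core. Set beside the earlier step, the same change did not behave alike on the two cores: the same change on two cores in this assay, a number 12 percentage points lower (beyond the scatter) from compound 3 to compound 1 and a number 2.3 percentage points higher (within the scatter) from compound 2 to compound 4, 14.3 percentage points apart, beyond the scatter of two such steps. This shows that a step seen on one core cannot simply be assumed on the other, but with one pair per core it does not show which feature of the cores sets the two steps apart.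

The compounds shown leave open how an amine or ethoxy in the same place would act on each core. They also leave open whether either step would hold on a third core.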